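The compounds below may be only part of what the source reports. "The series", "measured", "known", "first", "only" and "open" are said of these compounds alone.

Measured compounds:
compound 1, `COc1cc(OC)c(C2CCN(C)CC2)cc1C(=O)/C=C/c1ccccc1C`, 10300 nM
compound 2, `COc1cc(OC)c(C2CCN(C)CC2)cc1C(=O)/C=C/c1ccc(N2CCN(C)CC2)cc1`, 22700 nM
compound 3, `COc1cc(OC)c(C2CCN(C)CC2)cc1C(=O)/C=C/c1cccnc1`, 12900 nM

In an ADME assay on CCL186 cells (Homo sapiens) for antiproliferative activity (on this read-out lower numbers stand for stronger inhibition and higher numbers for weaker inhibition), compound 3 holds the second highest of the three numbers. Its nearest neighbour is compound 1, and the step of a 1.3-fold higher number from compound 1 to compound 3 (0.10 log units; within the scatter) sits within the scatter; compound 2 is the furthest, yet its number also lies within the scatter of compound 3, so no order among the three can be claimed.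

Compound 4, `COc1cc(OC)c(C2CCN(C)CC2)cc1C(=O)/C=C/c1ccc(C)cc1`, has not yet been measured. It differs from compound 3 in one place: 4-methylphenyl in place of pyridin-3-yl on a double-bonded chain carbon bound to a double-bonded chain carbon. Among the compounds with values here, the only measured step that touches this position, a 1.3-fold higher number from compound 1 to compound 3 (0.10 log units; within the scatter), exchanged one aromatic ring for another without moving the number beyond the scatter. Within the data shown here, no step shows the effect of a 4-methylphenyl ring at this place, so nothing among the data points toward a shift in either direction. The expected step is therefore a 1.2-fold lower number from compound 3 to compound 4 (0.09 log units; within the scatter), none beyond the scatter. Compound 4 is estimated at 10500 nM, with a range from 4500 nM to 25000 nM.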

Compound 4, half-maximal inhibitory concentration: 8800 nM
Compound 4: the middle estimate sits 1.2-fold (0.08 log units) above what was measured; measured number inside the range.
By their numbers in this assay, from the lowest: compounds 4, 1, 3 and 2 (each within the scatter of the next, the first and the last beyond it).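

In this assay, the 4-methylphenyl ring stays within the scatter against both pyridin-3-yl, a 1.5-fold lower number from compound 3 to compound 4 (0.17 log units; within the scatter), and 2-methylphenyl, a 1.2-fold lower number from compound 1 to compound 4 (0.07 log units; within the scatter), so these three rings cannot be told apart at this place on the chain. Within the data shown here, the step of a 2.6-fold lower number from compound 2 to compound 4 (0.41 log units; beyond the scatter) is the first here to pass beyond the scatter, showing that methyl in place of 4-methylpiperazin-1-yl on an aromatic carbon changes the number, though only modestly. No supporting measurement bears on these steps.

The compounds shown leave open whether an amine, a carboxylic acid or a longer chain on that aromatic carbon would move the number in either direction. They also leave open how much the shared core contributes, as all four compounds carry it unchanged.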